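One Amine Swap Carried Across Two Compound Pairs

This account rests on a few compounds, and the source may have more. Where it says the series, first, only, none or still open, it means among the compounds named here.

Compound 1 `COc1cc2c(Oc3ccc(NC(=O)c4nn(-c5ccccc5OC(F)(F)F)c(=O)cc4C)cc3F)ccnc2cc1OCCCN1CCC(C)CC1` and compound 2 `COc1cc2c(Oc3ccc(NC(=O)c4nn(-c5ccccc5OC(F)(F)F)c(=O)cc4C)cc3F)ccnc2cc1OCCCN1CCN(C)CC1` share one core and differ in a single place. In a functional assay on HT-29 cells (Homo sapiens) for inhibition, read by MTT assay, with a stated time of 72 h (on this read-out higher numbers stand for weaker inhibition and lower numbers for stronger inhibition), compound 1 gives 250 nM, and compound 2 gives 180 nM, so the change 4-methylpiperazin-1-yl in place of 4-methylpiperidin-1-yl on a saturated chain carbon, three bonds along the chain from an oxygen on an aromatic ring made a 1.4-fold lower number from compound 1 to compound 2 (0.14 log units; within the scatter). Compound 3 `COc1cc2c(Oc3ccc(NC(=O)c4nn(-c5cccc(F)c5)c(=O)cc4C)cc3F)ccnc2cc1OCCCN1CCC(C)CC1` carries the core of compound 1 with the difference (3-fluorophenyl in place of 2-(trifluoromethoxy)phenyl on an aromatic nitrogen); in this assay compound 3 gives 300 nM, which reads as a 1.2-fold higher number from compound 1 to compound 3 (0.08 log units; within the scatter). Compound 4 `COc1cc2c(Oc3ccc(NC(=O)c4nn(-c5cccc(F)c5)c(=O)cc4C)cc3F)ccnc2cc1OCCCN1CCN(C)CC1` has not been measured. It stands to compound 3 as compound 2 stands to compound 1, the change being (4-methylpiperazin-1-yl in place of 4-methylpiperidin-1-yl on a saturated chain carbon, three bonds along the chain from an oxygen on an aromatic ring), the same change at the same place. Because the earlier step was a 1.4-fold lower number from compound 1 to compound 2 (0.14 log units; within the scatter), the expected step is a 1.4-fold lower number from compound 3 to compound 4 (0.14 log units; within the scatter). On that basis compound 4 is estimated at 215 nM. The likely range for compound 4 runs from 110 nM to 430 nM.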

Compound 4, half-maximal inhibitory concentration: 250 nM
Compound 4: the middle estimate sits 1.2-fold (0.07 log units) below what was measured, and the stated range covers the measured number.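

In this assay, the amine swap gives a 1.2-fold lower number from compound 3 to compound 4 (0.08 log units; within the scatter), and its two readings agree: the same change on two cores in this assay, a 1.4-fold lower number (0.14 log units; within the scatter) from compound 1 to compound 2 and a 1.2-fold lower number (0.08 log units; within the scatter) from compound 3 to compound 4, 1.2-fold (0.06 log units) apart, within the scatter of two such steps. The change on the aromatic nitrogen, read with 4-methylpiperazin-1-yl in place, gives a 1.4-fold higher number from compound 2 to compound 4 (0.14 log units; within the scatter), and it agrees with its earlier reading too: the same change on two cores in this assay, a 1.2-fold higher number (0.08 log units; within the scatter) from compound 1 to compound 3 and a 1.4-fold higher number (0.14 log units; within the scatter) from compound 2 to compound 4, 1.2-fold (0.06 log units) apart, within the scatter of two such steps. Each change therefore carries between these two cores without a discernible shift, but every step lies within the scatter, so the data show neither that either change has a real effect of its own nor that this agreement would hold on another core.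

Still open, going by these compounds, is whether a morpholine or a dimethylamino group at the chain end, or a longer chain, would give a step beyond the scatter. The same question stands for a pyridyl or an unsubstituted phenyl on the aromatic nitrogen.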